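Adding One Fluoro to Compound 2

This account rests on a few compounds, and the source may have more. Where it says the series, first, only, none or still open, it means among the compounds named here.

In a functional assay on HCT-116 cells (Homo sapiens) for antiproliferative activity, read by CellTiter-Glo, with a stated time of 72 h (on this read-out higher numbers stand for weaker inhibition and lower numbers for stronger inhibition), compound 1 `O=C(NO)c1ccc(/C=C/c2ccnc(-c3cc(F)ccc3O)c2)cc1` gives 2040 nM and compound 2 `Cc1ccc(-c2cc(/C=C/c3ccc(C(=O)NO)cc3)ccn2)c(F)c1` gives 800 nM as the lower of the two numbers. Compound 3 `Cc1ccc(-c2cc(/C=C/c3ccc(C(=O)NO)cc3)c(F)cn2)c(F)c1` differs from compound 2 by fluoro in place of hydrogen on an aromatic carbon with the rest unchanged. Within the data shown here, the only measured step of a 2.6-fold lower number from compound 1 to compound 2 (0.41 log units; beyond the scatter) is modest and involved a different change, so it is just a rough guide to size. No step beyond the scatter is expected, so the estimated change in this assay is a 1.1-fold lower number from compound 2 to compound 3 (0.03 log units; within the scatter) with no firm direction. Compound 3 is estimated at 750 nM with 300 nM to 1800 nM as its expected range.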

Compound 3, half-maximal inhibitory concentration: 1670 nM
Compound 3: middle estimate off by 2.2-fold (0.35 log units), on the low side, and the stated range covers the measured number.
By their numbers in this assay, from the lowest: compound 2; then compounds 3 and 1 (each within the scatter of the next).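

In this assay, this ring carbon, ortho to a large group and two atoms from the ring nitrogen, proves sensitive, with a 2.1-fold higher number from compound 2 to compound 3 (0.32 log units; beyond the scatter) as the result of swapping one hydrogen for fluoro. The earlier step changed the 2-fluoro-4-methylphenyl side instead, so only now is it clear that one added fluorine atom on the core can shift the number towards weaker inhibition. Nothing measured here explains this shift. The compounds shown leave open whether a chloro, a methyl or an amine on this same carbon would move the number the same way.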